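Bromo to Acetyl: Expecting the Lipophilicity of Compound 4

The compounds below may be only part of what the source reports. "The series", "measured", "known", "first", "only" and "open" are said of these compounds alone.

The measured compounds, in a physicochemical assay for lipophilicity, measured as octanol-water partition, at pH 7.4; on this read-out higher numbers stand for higher lipophilicity and lower numbers for lower lipophilicity:
compound 1 `CC(=O)c1cccc(NC2=NCCC3(CCCCC3)S2)c1` gives 2.37
compound 2 `CC(C)c1ccc(NC2=NCCC3(CCCCC3)S2)cc1` gives 1.57
compound 3 `Brc1ccc(NC2=NCCC3(CCCCC3)S2)cc1` gives 2.53

Compound 3 stands highest of the three numbers. Its nearest neighbour is compound 1, whose value lies within the scatter of it, so no order between those two can be claimed; compound 2 lies furthest away, beyond the scatter. The one step with a listed difference is a number 0.96 log units higher from compound 2 to compound 3 (beyond the scatter), a modest rise.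

Compound 4 `CC(=O)c1ccc(NC2=NCCC3(CCCCC3)S2)cc1` has not yet been measured in this assay. It differs from compound 3 as follows: acetyl in place of bromo on an aromatic carbon. For the measured compounds named here, no measured step covers an acetyl entering in place of a bromo, so the step from compound 2 to compound 3 bears on it only indirectly, by showing that exchanging the group at this place can shift the read-out by close to one unit. The most informative comparison is compound 1, which carries an acetyl at a different place on the same ring and gives a value within the scatter of compound 3.

Drawing on compound 1 and its value 2.37, compound 4 is expected to come in somewhat lower than compound 3, with a number 0.38 log units lower from compound 3 to compound 4 (beyond the scatter) as the estimated step, though a step within the scatter cannot be excluded. Compound 4 is therefore estimated at 2.15, with a range from 1.55 to 2.75.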

Compound 4, distribution coefficient: 1.97
Beside the measured number, compound 4's estimate is 0.18 log units above it; the measured number falls inside the stated range.
By their numbers in this assay, from the lowest: compound 2; then compound 4; then compounds 1 and 3 (each within the scatter of the next).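

In this assay, the exchange on an aromatic carbon para to a large group gives a number 0.56 log units lower from compound 3 to compound 4 (beyond the scatter), as acetyl, with its hydrogen-bond acceptor and 3 heavy atoms, enters where bromo, with 1 heavy atom, stood. The acetyl group also gives a number 0.40 log units higher from compound 2 to compound 4 (beyond the scatter), and together with a number 0.96 log units higher from compound 2 to compound 3 (beyond the scatter) this places the three groups at this position in a clear order, from isopropyl through acetyl to bromo, with every step beyond the scatter. No measured evidence here accounts for that order.

With the acetyl at a different place on the ring, compound 1 gives 2.37, while compound 4 gives 1.97, but this single pair leaves open how far the place of a group matters in general across the series. Also open, going by these compounds, is whether an amine, a carboxylic acid or a longer chain at this position would fall within the span set by isopropyl and bromo or outside it.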